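The source may report more compounds than this note shows. Statements on the series, on what has been measured and on what is new or still open speak of the compounds shown alone.

Compound 1 `O=C(NCCNS(=O)(=O)c1ccc(-c2ccccc2Oc2ccc(O)c(O)c2)s1)Nc1cc(Cl)cc(Cl)c1` gives the highest number of the three measured compounds in a functional assay on HL-60 cells (Homo sapiens) for inhibition, read by CCK-8 assay, with a stated time of 48 h (on this read-out lower numbers stand for stronger inhibition and higher numbers for weaker inhibition), with compound 1 at 10400 nM. Compound 3 `O=[N+]([O-])c1ccc(Oc2ccc(O)c(O)c2)c(-c2ccsc2S(=O)(=O)N2CCN(C(=S)Nc3cc(C(F)(F)F)cc(C(F)(F)F)c3)CC2)c1` gives 8400 nM in this assay, which lies within the scatter of compound 1. Compound 2 `Cc1cc(C)cc(NC(=O)NCCNS(=O)(=O)c2ccc(-c3ccccc3OCc3ccccc3)s2)c1` differs from compound 1 in more than one place; in this assay compound 2 gives 2200 nM, a number clearly lower than that of compound 1. Compound 4 `O=C(NCCNS(=O)(=O)c1ccc(-c2ccccc2OCc2cccc(O)c2)s1)Nc1cc(Cl)cc(Cl)c1` is not yet measured. It differs from compound 1 by 3-hydroxybenzyl in place of 3,4-dihydroxyphenyl on an oxygen on an aromatic ring. Going by the values given here, no single-change step among the measured compounds bears directly on this change, so the expected step of a 2.1-fold lower number from compound 1 to compound 4 (0.32 log units; beyond the scatter) in this assay is a modest move toward a lower number, and no step beyond the scatter would not surprise. Compound 4 is therefore estimated at 5000 nM in this assay, within a range from 1500 nM to 15000 nM.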

Compound 4, half-maximal inhibitory concentration: 2800 nM
Compound 4: middle estimate off by 1.8-fold (0.25 log units), on the high side, and the stated range covers the measured number.
By their numbers in this assay, from the lowest: compounds 2 and 4 (each within the scatter of the next); then compounds 3 and 1 (each within the scatter of the next).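

Exchanging 3,4-dihydroxyphenyl for 3-hydroxybenzyl on this oxygen gives, in this assay, a 3.7-fold lower number from compound 1 to compound 4 (0.57 log units; beyond the scatter), the only single-change step shown at this position. The number therefore responds to this group, even though the leaving and entering groups hold the same number of heavy atoms. No measurement on hand accounts for the step. The compounds shown leave open how 3,4-dihydroxybenzyl would stand on the same oxygen, which would separate the added benzyl carbon from the lost hydroxyl, and whether an amine or a carboxylic acid could replace that group's hydroxyl.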